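The source may hold more compounds than are shown below. What is called first, only, known or untested is meant among the compounds shown, and "the series" means these compounds.

Measured so far: compound 1 `CC/C(=C(/c1ccc(/C=C/C(=O)O)cc1)c1ccc2[nH]ncc2n1)c1ccccc1` with 33 nM in a functional assay on MCF7 cells (Homo sapiens) for cytotoxicity, read by CellTiter-Glo, with a stated time of 5 days (on this read-out lower numbers stand for stronger inhibition and higher numbers for weaker inhibition), and compound 2 `CC/C(=C(/c1ccc(/C=C/C(=O)O)cc1)c1cnc2[nH]ncc2c1)c1ccccc1` with 302 nM in this assay.

Among the measured compounds shown here, on these two numbers compound 2 stands highest, its only neighbour being compound 1, which lies a 9.2-fold higher number from compound 1 to compound 2 (0.96 log units; beyond the scatter) away in the other direction. Compound 3 `CC/C(=C(/c1ccc(/C=C/C(=O)O)cc1)c1ccc2[nH]nc(C)c2c1)c1ccccc1` differs from compound 2 in one place: a group of 10 heavy atoms (8 carbon, 2 nitrogen; one five-membered aromatic ring with 2 hetero atoms, one six-membered aromatic ring of carbon only) in place of a group of 9 heavy atoms (6 carbon, 3 nitrogen; one five-membered aromatic ring with 2 hetero atoms, one six-membered aromatic ring with 1 hetero atom), on a double-bonded chain carbon bound to an aromatic carbon and a double-bonded chain carbon. For the measured compounds named here, no measured step in this assay involves the group that enters, so the only guide is the size of the move seen from compound 1 to compound 2, where swapping one fused bicyclic for another of the same atom count gave a 9.2-fold higher number from compound 1 to compound 2 (0.96 log units; beyond the scatter). A change of comparable kind at the same place is expected to move the number by a similar amount, and with compound 2 at the high end the expected direction is downward, toward the value of compound 1. Compound 3 is therefore estimated at 45 nM, with a range from 10 nM to 200 nM, meaning an expected step of a 6.7-fold lower number from compound 2 to compound 3 (0.83 log units; beyond the scatter).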

Compound 3, half-maximal inhibitory concentration: > 1000 nM
Compound 3 gave a limit, no number; the forecaster's own chance of this, stated with the estimate: 0%; at least 22-fold (1.34 log units) between middle value and limit.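

In this assay compound 3 gave no number, only a limit of the assay: the limit of > 1000 nM in this assay, at which 1 of the 3 values shown sits.

Even so, the step can be read as a lower bound, and it runs upward at this place on the double-bonded chain carbon: an at least 3.3-fold higher number from compound 2 to compound 3 (0.51 log units; beyond the scatter), and an at least 30-fold higher number from compound 1 to compound 3 (1.48 log units; beyond the scatter). Among the three groups shown here, 3-methyl-1H-indazol-5-yl, with its six-membered aromatic ring of carbon only and its single hydrogen-bond acceptor, goes with the highest number, so the earlier gap between compound 1 and compound 2 was not the full span at this place.

The change swaps a ring nitrogen for carbon and adds a methyl in one move, so the compounds shown do not tell which of the two goes with the rise. From the compounds shown here alone, how an amine or a chlorine in place of that methyl would read also stays open, as does how far compound 3 lies beyond its limit.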